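The source may hold more compounds than are shown below. What is called first, only, known or untested is meant among the compounds shown, and "the series" means these compounds.

Working notes on the series in an ADME assay on HEK293 cells (Homo sapiens) for cytotoxicity, read by CCK-8 assay and cell counting, with a stated time of 2 days; on this read-out higher numbers stand for weaker inhibition and lower numbers for stronger inhibition.

Three compounds sharing one core have numbers. Compound 1 `Oc1ccc(-c2cc(-c3cccs3)nc(-c3ccccc3Cl)c2)cc1` gives 5220 nM in this assay. Compound 2 `Oc1ccc(-c2cc(-c3ccc(Cl)cc3)nc(-c3cccs3)c2)cc1` gives 4520 nM. Compound 3 `Oc1ccc(-c2cc(-c3cccc(Cl)c3)nc(-c3cccs3)c2)cc1` gives 2720 nM. Compound 2 holds the middle number of the three: its nearest neighbour is compound 1 with a 1.2-fold lower number from compound 1 to compound 2 (0.06 log units; within the scatter), and its furthest is compound 3 with a 1.7-fold lower number from compound 2 to compound 3 (0.22 log units; within the scatter); the remaining pair shows a 1.9-fold lower number from compound 1 to compound 3 (0.28 log units; within the scatter). All three steps stay within the scatter, so no ordering among these compounds can be read from them.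

Compound 4 `Oc1ccc(-c2cc(-c3ccc(Cl)cc3)nc(-c3ccco3)c2)cc1` is not yet measured. It differs from compound 2 by furan-2-yl in place of thiophen-2-yl on an aromatic carbon. Within the data shown here, none of the measured steps touches this part of the molecule: each of them exchanges 2-chlorophenyl, 3-chlorophenyl and 4-chlorophenyl among themselves while thiophen-2-yl is kept throughout. Among the measured compounds shown here, the exchange of thiophen-2-yl for furan-2-yl therefore has no direct precedent in this set. Given that every measured step in this assay stayed within the scatter and that the change is a like-for-like swap of one five-membered aromatic ring for another, no step beyond the scatter is expected, and the estimated step is a 1.0-fold lower number from compound 2 to compound 4 (0.00 log units; within the scatter). Compound 4 is expected to give about 4500 nM, in the range 1800 nM to 11000 nM.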

Compound 4, half-maximal inhibitory concentration: 5720 nM
For compound 4 the middle estimate is 1.3-fold (0.10 log units) below the measured one; the range from low to high includes it.
By their numbers in this assay, from the lowest: compounds 3, 2, 1 and 4 (each within the scatter of the next, the first and the last beyond it).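

Among these compounds, the position next to the ring nitrogen now has a measured step for the first time: in this assay, furan-2-yl in place of thiophen-2-yl, with the 4-chlorophenyl group kept, gives a step within the scatter (a 1.3-fold higher number from compound 2 to compound 4 (0.10 log units; within the scatter)). Among the compounds shown here, the earlier steps varied only the chlorophenyl group, so this is the first sign that the thiophen-2-yl group can be exchanged at this position without a step beyond the scatter, though the sign rests on this single pair and on two five-membered aromatic rings with the same counts of heavy atoms and hydrogen-bond acceptors. No supporting evidence is available to explain this result.

It remains open whether the same exchange stays within the scatter when 2-chlorophenyl or 3-chlorophenyl replaces the 4-chlorophenyl group, as the furan-2-yl group is shown with the 4-chlorophenyl group only. From the compounds shown here alone, it also remains open how this assay responds when this position carries a group of another kind, such as an amine, a carboxylic acid or a longer alkyl chain.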